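Bromo for Methoxy: an Expected Near-Neutral Step

This account rests on a few compounds, and the source may have more. Where it says the series, first, only, none or still open, it means among the compounds named here.

Going by the values given here, in a functional assay on PC-3 cells (Homo sapiens) for antiproliferative activity, read by MTT assay, with a stated time of 72 h (on this read-out higher numbers stand for weaker inhibition and lower numbers for stronger inhibition), compound 1 `COc1ccccc1/C=C/C(=O)c1ccc(OCC(=O)N[C@H]2CCOC2=O)cc1` gives 7240 nM, the only numerical value among the three compounds measured so far. Compound 2 `CCCCCCCCCCSC(=S)N[C@H]1CCOC1=O` reaches only a limit of the assay, > 64000 nM. Compound 3 `O=C(CNc1ccccc1)N[C@H]1CCOC1=O` likewise reaches only a limit, > 64000 nM. The other two measurements thus sit at the limit of > 64000 nM in this assay, at which 2 of the 3 values shown sit. Among the compounds with values here, compound 1 therefore stands alone as the one compound with a measurable result. Within the data shown here, no two measured compounds differ in a single place; there is no measured step to show how a change of this kind shifts the read-out.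

Compound 4 `O=C(COc1ccc(C(=O)/C=C/c2ccccc2Br)cc1)N[C@H]1CCOC1=O`, not yet measured, differs from compound 1 by bromo in place of methoxy on an aromatic carbon, or, read one bond further out, 2-methoxyphenyl to 2-bromophenyl. Among the measured compounds shown here, with no measured step to lean on, and with nothing in the data that marks this aromatic position as sensitive, the expected step is small, in either direction, and most likely within the scatter of repeated measurements. The step of a 1.1-fold lower number from compound 1 to compound 4 (0.05 log units; within the scatter) is expected to be close to none. Compound 4 is accordingly estimated at 6500 nM, with a range from 2000 nM to 22000 nM in this assay.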

Compound 4, half-maximal inhibitory concentration: 3260 nM
Estimate against measurement, compound 4: 2.0-fold (0.30 log units) above, and the stated range covers the measured number.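

Going by these compounds alone, the step from methoxy to bromo gives, in this assay, a 2.2-fold lower number from compound 1 to compound 4 (0.35 log units; beyond the scatter), which is the first measured reading of this place and shows that a change on this aromatic carbon, ortho to a large group, can move the number beyond the usual scatter, if only modestly. The methoxy group, with its two heavy atoms and one hydrogen-bond acceptor, can also give way to bromo, with one heavy atom and no acceptor, without any loss in the read-out, so the methoxy group is not required for the inhibition that compound 1 shows here. Nothing in the data shown accounts for the size or the direction of this step.

The compounds shown leave open how a chloro group, an amine or a carboxylic acid on the same aromatic carbon would read, and so whether the read-out follows any trend across groups at this place. Also open, as far as these compounds go, is whether bromo on another carbon of this ring would give a step of similar size, or whether this step belongs to this one position.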